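This account rests on a few compounds, and the source may have more. Where it says the series, first, only, none or still open, it means among the compounds named here.

Working notes on the series. In a functional assay on MKN-74 cells (Homo sapiens) for antiproliferative activity, with a stated time of 24 h (on this read-out lower numbers stand for stronger inhibition and higher numbers for weaker inhibition), compound 1 (`NC(=O)c1c(NC(=O)c2ccccc2Cl)sc2c1CCNC2`), with hydrogen on the amine nitrogen in the ring, gives 28700 nM. With 2-cyanobenzyl on that nitrogen, compound 2 (`N#Cc1ccccc1CN1CCc2c(sc(NC(=O)c3ccccc3Cl)c2C(N)=O)C1`) gives 9500 nM, and with 4-chlorobenzyl, compound 3 (`NC(=O)c1c(NC(=O)c2ccccc2Cl)sc2c1CCN(Cc1ccc(Cl)cc1)C2`) gives 18700 nM.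

Of the two gaps around compound 2, only one lies beyond the scatter: a 3.0-fold lower number from compound 1 to compound 2 (0.48 log units; beyond the scatter). The other, a 2.0-fold higher number from compound 2 to compound 3 (0.29 log units; within the scatter), lies within it, so these two compounds cannot be ranked. The remaining comparison, a 1.5-fold lower number from compound 1 to compound 3 (0.19 log units; within the scatter), also stays within the scatter.

Compound 4 (`NC(=O)c1c(NC(=O)c2ccccc2Cl)sc2c1CCN(Cc1c(Cl)cccc1Cl)C2`) has 2,6-dichlorophenyl in place of the 2-cyanophenyl of compound 2, on a saturated chain carbon bound to an amine nitrogen in a ring: 2,6-dichlorophenyl in place of 2-cyanophenyl on a saturated chain carbon bound to an amine nitrogen in a ring.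

The closest measured precedent is a 2.0-fold higher number from compound 2 to compound 3 (0.29 log units; within the scatter), which replaces the same 2-cyanophenyl at the same place. Among the compounds with values here, no measured compound carries 2,6-dichlorophenyl, so this precedent is only a partial guide. No step beyond the scatter is therefore expected, with at most a slight drift towards a higher number.

The expected change is a 1.4-fold higher number from compound 2 to compound 4 (0.14 log units; within the scatter).

For compound 4 the estimated value is 13000 nM, with an expected range from 6000 nM to 28000 nM.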

Compound 4, half-maximal inhibitory concentration: 4740 nM
The estimate for compound 4 lay 2.7-fold (0.44 log units) above the measured number, and the stated range ends above it.
By their numbers in this assay, from the lowest: compounds 4, 2, 3 and 1 (each within the scatter of the next, the first and the last beyond it).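

Within the data shown here, compound 4 gives the first step beyond the scatter between two chlorine-bearing benzyl groups on this nitrogen, (a 3.9-fold lower number from compound 3 to compound 4 (0.60 log units; beyond the scatter)), so the number or placing of the chlorines on the benzyl group goes with the read-out, and the mere presence of chlorine does not. The nitrile of compound 2 and its hydrogen-bond acceptor can be exchanged for 2,6-dichlorophenyl with no order to be read, (a 2.0-fold lower number from compound 2 to compound 4 (0.30 log units; within the scatter)), while a 6.1-fold lower number from compound 1 to compound 4 (0.78 log units; beyond the scatter) makes this the second substituted benzyl group beyond the scatter from the hydrogen of compound 1; compound 3 goes against any general gain from a benzyl group at this place. Nothing available explains why the 2,6-dichlorobenzyl and 4-chlorobenzyl groups part in this way.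

The compounds shown leave open where a plain benzyl or a 2-chlorobenzyl group would fall, and so whether one chlorine in the 2-position would be enough or both are needed. They also leave open whether a basic amine or a carboxylic acid on a longer chain at this nitrogen would fit with the benzyl groups seen so far.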